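This account rests on a few compounds, and the source may have more. Where it says the series, first, only, none or still open, it means among the compounds named here.

Compound 2 `COc1nc2ccccc2cc1/C=C/c1noc(-c2ccc(Br)cc2)n1` is one of three congeners sharing a core. In an ADME assay on HepG2 cells (Homo sapiens) for cytotoxicity, read by sulforhodamine B assay, with a stated time of 48 h (a lower number here means that less compound is tolerated, a higher number that more compound is tolerated), compound 2 gives > 195000 nM, a limit of the assay rather than a number. Compound 1 `COc1nc2ccccc2cc1/C=C/c1noc(-c2ccc(C)cc2)n1` gives > 230000 nM in this assay, also a limit. Compound 3 `COc1nc2ccccc2cc1/C=C/c1noc(-c2ccccc2Br)n1` gives > 195000 nM in this assay, again a limit. The steps a step that the two limits leave unreadable from compound 1 to compound 2 and a step that the two limits leave unreadable from compound 2 to compound 3 are therefore unreadable, and nothing puts compound 2 apart from the others; two of the three values rest at the limit of > 195000 nM in this assay, at which 2 of the 3 values shown sit.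

Compound 4 `COc1cccc(-c2nc(/C=C/c3cc4ccccc4nc3OC)no2)c1` differs from compound 2 by 3-methoxyphenyl in place of 4-bromophenyl on an aromatic carbon. For the measured compounds named here, since no measured step shows any change beyond the scatter, compound 4 is expected to sit likewise at the limit, and the step that the limit leaves unreadable from compound 2 to compound 4 is estimated as essentially none. Compound 4 is thus estimated at 200000 nM, in the range 90000 nM to 300000 nM.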

Compound 4, half-maximal cytotoxic concentration: > 220000 nM
Compound 4: a limit, no number; the forecaster's own chance of this, stated with the estimate: 80%; at least 1.1-fold (0.04 log units) between middle value and limit.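

For the compounds shown here, compound 4 also gives only a limit in this assay, so no step from it to compound 1, compound 2 or compound 3 can be read. The compounds shown leave open at what concentration, if any, each of the four becomes cytotoxic.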